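The compounds below may be only part of what the source reports. "The series", "measured", "known", "first", "only" and "open" are said of these compounds alone.

compound 1 `COc1cc(Sc2c[nH]c3ccccc23)cc(OC)c1OC`: 34 nM
compound 2 `COc1cc(Sc2c[nH]c3ccc(N)cc23)cc(OC)c1OC`: 260 nM
compound 3 `COc1cc(Sc2c[nH]c3ccc(C)cc23)cc(OC)c1OC`: 16 nM

All three were tested in a functional assay on MCF7 cells (Homo sapiens) for inhibition, with a stated time of 48 h; a lower number here means a stronger inhibitor, a higher number a weaker inhibitor. Among them, compound 3 gives 16 nM, the lowest number and so the strongest inhibition of the set.

The next compound is compound 4 `COc1cc(Sc2c[nH]c3ccc(OC(C)C)cc23)cc(OC)c1OC`, in which isopropoxy takes the place of methyl on an aromatic carbon of the shared core: isopropoxy in place of methyl on an aromatic carbon.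

Among the measured compounds shown here, three measured steps bear on this change. Methyl in place of hydrogen gave a 2.1-fold lower number from compound 1 to compound 3 (0.33 log units; beyond the scatter), a modest gain. Amino in place of hydrogen gave a 7.6-fold higher number from compound 1 to compound 2 (0.88 log units; beyond the scatter), a modest loss. Methyl in place of amino gave a 16-fold lower number from compound 2 to compound 3 (1.21 log units; beyond the scatter), a large step. Changing the group here can therefore move the number either way. For the measured compounds named here, no measured compound carries isopropoxy or any other oxygen-linked group, so the evidence is thin. The nearest guide is compound 2 at 260 nM, whose replacement group is also not linked through carbon, and it is weaker than compound 1 at 34 nM.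

A loss of inhibition is therefore expected, with the estimated change being a 6.3-fold higher number from compound 3 to compound 4 (0.80 log units; beyond the scatter). The estimate for compound 4 is 100 nM, with an expected range of 20 nM to 500 nM.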

Compound 4, half-maximal inhibitory concentration: 1500 nM
Compound 4: the middle estimate sits 15-fold (1.18 log units) below what was measured; the measured number lies above the stated range.
By their numbers in this assay, from the lowest: compound 3; then compound 1; then compound 2; then compound 4.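

In this assay, isopropoxy is the weakest of the four groups at this position on the shared core: placing it where compound 1 has hydrogen gives a 44-fold higher number from compound 1 to compound 4 (1.64 log units; beyond the scatter), and placing it where compound 3 has methyl gives a 94-fold higher number from compound 3 to compound 4 (1.97 log units; beyond the scatter). Among the compounds shown here, it also falls short of amino, the only group that had lowered inhibition so far (a 5.8-fold higher number from compound 2 to compound 4 (0.76 log units; beyond the scatter)), so this position can lose far more than compound 2 had suggested. Group size alone does not set the order, since methyl, with more heavy atoms than hydrogen, gives the stronger inhibitor, while isopropoxy, with more heavy atoms still, gives the weakest; nothing available explains this reversal.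

The compounds shown leave open whether the loss goes with the oxygen link or with the branched chain, and methoxy and isopropyl on this carbon would help separate the two. They also leave open how a halogen such as chlorine or a longer carbon chain such as propyl would compare with methyl here.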